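Acid to dimethylamide on the pendant ring: lipophilicity estimate

A few compounds are considered here, and "the series" means these few. Any claim that something is new, unique, unknown or untested is made for them only; others in the source may bear on it.

Three compounds of the series have numbers in a physicochemical assay for lipophilicity, at pH 7.4; a higher number here means a more lipophilic compound, a lower number a more polar compound. Compound 1 `COc1ccc(-c2cc(-c3ccc(S(=O)(=O)N(C)C)cc3)cnc2N)cn1` gives 2.8. Compound 2 `COc1ccc(-c2cc(-c3ccc(C(F)(F)F)cc3)cnc2N)cn1` gives 4.2. Compound 3 `COc1ccc(-c2cc(-c3ccc(C(=O)O)cc3)cnc2N)cn1` gives 0.8, the lowest of the three; the nearest is compound 1, the furthest compound 2. The measured steps are all large: a number 1.40 log units higher from compound 1 to compound 2 (beyond the scatter), a number 2.00 log units lower from compound 1 to compound 3 (beyond the scatter), and a number 3.40 log units lower from compound 2 to compound 3 (beyond the scatter).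

Compound 4 `COc1ccc(-c2cc(-c3ccc(C(=O)N(C)C)cc3)cnc2N)cn1` is not yet measured. It differs from compound 3 by dimethylamino in place of hydroxy on a carbonyl carbon. Within the data shown here, no measured step changes a carboxy into a dimethylcarbamoyl, so none bears on it directly. The closest guide is the step from compound 1 to compound 3, a number 2.00 log units lower from compound 1 to compound 3 (beyond the scatter), in which carboxy replaced dimethylsulfamoyl; compound 4 carries dimethylamino on its substituent as compound 1 does on its sulfonyl group. A step of roughly that size in the opposite direction is therefore expected in this assay , up from compound 3.

The estimate for compound 4 is 2.7, with a range from 2 to 3.4, which means an expected step of a number 1.90 log units higher from compound 3 to compound 4 (beyond the scatter).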

Compound 4, distribution coefficient: 2.1
Compound 4: middle estimate off by 0.60 log units, on the high side; the measured number falls inside the stated range.
By their numbers in this assay, from the lowest: compound 3; then compound 4; then compound 1; then compound 2.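

In this assay, keeping the carbonyl carbon and changing only what it carries gives a number 1.30 log units higher from compound 3 to compound 4 (beyond the scatter), so hydroxy and dimethylamino at this one place are clearly separated by the read-out. Dimethylcarbamoyl and dimethylsulfamoyl, although both carry dimethylamino, are not equivalent on the aromatic carbon: the series shows a number 0.70 log units lower from compound 1 to compound 4 (beyond the scatter), a modest step, against the large a number 2.10 log units lower from compound 2 to compound 4 (beyond the scatter), which places dimethylcarbamoyl between carboxy and dimethylsulfamoyl in this four-compound set, with trifluoromethyl highest. No measurement at hand accounts for the sizes of these steps.

The compounds shown leave open how much of the step from carboxy to dimethylcarbamoyl goes with the removal of the hydrogen-bond donor and how much with the two added carbons, a question that a plain carboxamide or a methylamino group on the same carbonyl carbon would address. Also open, going by these compounds, is whether a cyclic amide such as a morpholine amide or a longer chain on the amide nitrogen would follow the same trend.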